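Two aryl-linker swaps on a shared pyrazolopyrimidine-free core

This account rests on a few compounds, and the source may have more. Where it says the series, first, only, none or still open, it means among the compounds named here.

Measured compounds:
compound 1, `Cc1cc(-c2cnn3c(NCC4CCOCC4)nc(Oc4cccc(F)c4F)nc23)ccc1C(=O)NC1CC1`, 0.467 h
compound 2, `Cc1cc(-c2cnn3c(NCC4CCOCC4)nc(Nc4cccc(F)c4)nc23)ccc1C(=O)NC1CC1`, 0.5 h

In an ADME assay on microsomes (Mus musculus) for metabolic stability (on this read-out lower numbers stand for a shorter-lived compound and higher numbers for a longer-lived compound), compound 1 gives 0.467 h, the lowest of the two numbers recorded, and compound 2 gives 0.5 h. Among the measured compounds shown here, the only measured step, a 1.1-fold higher number from compound 1 to compound 2 (0.03 log units; within the scatter), exchanges the aryl ether for an aryl amine and stays within the scatter.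

Compound 3, `Cc1cc(-c2cnn3c(NCC4CCOCC4)nc(Nc4ccccc4F)nc23)ccc1C(=O)NC1CC1`, has not been measured in this assay. It differs from compound 1 by (2-fluorophenyl)amino in place of 2,3-difluorophenoxy on an aromatic carbon. For the measured compounds named here, this change mirrors the one from compound 1 to compound 2 in kind, an oxygen link replaced by an amino link on the same aromatic carbon, and differs only in the fluorine pattern on the phenyl ring. Because a 1.1-fold higher number from compound 1 to compound 2 (0.03 log units; within the scatter) stayed within the scatter, no step beyond the scatter is expected for compound 3 either, so a 1.1-fold higher number from compound 1 to compound 3 (0.03 log units; within the scatter) is the expected outcome. Compound 3 is therefore estimated at 0.5 h, with a range from 0.25 h to 1 h.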

Compound 3, half-life: 0.283 h
Estimate against measurement, compound 3: 1.8-fold (0.25 log units) above; the range from low to high includes it.
By their numbers in this assay, from the lowest: compounds 3, 1 and 2 (each within the scatter of the next).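

In this assay, the position now carries two amino-linked aryl groups, which allows the fluorine placement to be read with the linking atom held constant: 2-fluorophenyl in place of 3-fluorophenyl on the nitrogen gives (a 1.8-fold lower number from compound 2 to compound 3 (0.25 log units; within the scatter)). The exchange of 2,3-difluorophenoxy for (2-fluorophenyl)amino gives (a 1.7-fold lower number from compound 1 to compound 3 (0.22 log units; within the scatter)), so neither of these steps, nor the earlier one, leaves the scatter, and the three compounds cannot be separated on half-life. Nothing recorded here offers an explanation for these results.

As far as these compounds go, it remains open whether a change larger than a fluorine shift or a linker swap would separate from the scatter at this position, such as an unsubstituted phenyl, a chlorophenyl or a saturated amine like morpholine. From the compounds shown here alone, the shared ((oxan-4-yl)methyl)amino group also stays the same throughout, so its part in the half-life is unknown.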